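The source may report more compounds than this note shows. Statements on the series, on what has been measured and on what is new or still open speak of the compounds shown alone.

Compound 1, `CN1CCC[C@H]1COc1cccnc1`: in an assay on a protein complex for binding affinity to Neuronal acetylcholine receptor; alpha3/beta4 (Rattus norvegicus) (a higher number here means a weaker inhibitor, a lower number a stronger inhibitor), compound 1 gives 1400 nM.
Compound 2, `CCCCC#Cc1cncc(OC[C@@H]2CCCN2C)c1`: in this assay compound 2 gives 40000 nM.
Compound 3, `CN1CCC[C@H]1COc1cncc(C#CCO)c1`: in this assay compound 3 gives 23000 nM.

Compound 2 has the highest number of the three. Compound 3 lies closest, separated by a 1.7-fold lower number from compound 2 to compound 3 (0.24 log units; within the scatter), while compound 1 is furthest away, separated by a 29-fold higher number from compound 1 to compound 2 (1.46 log units; beyond the scatter). Compound 4, `CN1CCC[C@H]1COc1cncc(C#CCCCCO)c1`, differs from compound 2 by hydroxy in place of hydrogen on a saturated chain carbon, four bonds along the chain from a triple-bonded carbon. Within the data shown here, one measured step bears on this: the hydroxy-bearing chain of compound 3 versus the plain chain of compound 2 gave a 1.7-fold lower number from compound 2 to compound 3 (0.24 log units; within the scatter), a step within the scatter. The large steps of a 29-fold higher number from compound 1 to compound 2 (1.46 log units; beyond the scatter) and a 16-fold higher number from compound 1 to compound 3 (1.22 log units; beyond the scatter) show that a chain of either kind on that aromatic carbon raises the number by a similar amount. For compound 4 the expectation is therefore no step beyond the scatter in this assay, that is a 1.3-fold lower number from compound 2 to compound 4 (0.12 log units; within the scatter). Compound 4 is estimated at 30000 nM, with a range from 10000 nM to 90000 nM.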

Compound 4, inhibition constant: 63000 nM
The estimate for compound 4 lay 2.1-fold (0.32 log units) below the measured number; the measured number falls inside the stated range.
By their numbers in this assay, from the lowest: compound 1; then compounds 3, 2 and 4 (each within the scatter of the next, the first and the last beyond it).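

In this assay, hydroxy in place of hydrogen, four bonds along the chain from a triple-bonded carbon, leaves the number within the scatter (a 1.6-fold higher number from compound 2 to compound 4 (0.20 log units; within the scatter)). Among the hydroxy-bearing chains, chain length does register: 3-hydroxypropyl in place of hydroxy gives a modest step (a 2.7-fold higher number from compound 3 to compound 4 (0.44 log units; beyond the scatter)), and the 6-hydroxyhex-1-yn-1-yl chain keeps a large step over hydrogen on the aromatic carbon (a 45-fold higher number from compound 1 to compound 4 (1.65 log units; beyond the scatter)). Nothing available explains these steps. On these data alone, whether an amine or a carboxylic acid in place of this hydroxy would bring the number back towards that of compound 1 stays open.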